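Compound 3 to compound 4: one more methoxy

The source may hold more compounds than are shown below. What is called first, only, known or untested is meant among the compounds shown, and "the series" means these compounds.

These notes follow a short series of methoxy variants on a shared core. Compound 1 is `COc1ccc(CNc2ncnc3c2ncn3C2CCCCO2)cc1`, compound 2 is `COc1ccc(CNc2ncnc3c2ncn3C2CCCCO2)c(OC)c1`, compound 3 is `COc1ccc(CNc2ncnc3c2ncn3C2CCCCO2)cc1OC`, and compound 4, not yet measured, is `COc1ccc(CNc2ncnc3c2ncn3C2CCCCO2)c(OC)c1OC`. All are read in an ADME assay on BJ cells (Homo sapiens) for cytotoxicity, read by MTT assay, with a stated time of 72 h; a higher number here means a weaker inhibitor, a lower number a stronger inhibitor.

In this assay compound 1 gives > 100000 nM, which is a limit and not a number. Compound 2 gives > 25000 nM, also a limit. Compound 3 gives > 100000 nM, again a limit, and it stands on that limit alone.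

The change to compound 4 is methoxy in place of hydrogen on an aromatic carbon. Two measured steps make the same kind of exchange: a step that the two limits leave unreadable from compound 1 to compound 2 and a step that the two limits leave unreadable from compound 1 to compound 3. Neither has a readable size, so neither gives a direction for the new step. With no measured number in the series, no shift beyond the scatter is expected in this assay, and the expectation stays close to the limit of compound 3.

The expected step is a number no higher from compound 3 to compound 4 (the limit leaves the size open), and it is an estimate resting on limits only.

For compound 4 the estimated value is 100000 nM, with an expected range of 30000 nM to 200000 nM.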

Compound 4, half-maximal inhibitory concentration: > 37500 nM
Compound 4 ended at the assay's limit (the forecaster's own chance of this, stated with the estimate: 85%); the middle value lies beyond the limit too.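

The steps from compound 2 and from compound 3 to compound 4 cannot be read in this assay, as all three compounds carry only limits and not numbers. The compounds shown leave open the size and direction of any exchange of methoxy for hydrogen on the aromatic carbons in this assay, with no number yet in the series.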